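This account rests on a few compounds, and the source may have more. Where it says the series, first, only, none or still open, it means among the compounds named here.

Measured in an assay on membranes from HEK293 cells for displacement of a labelled ligand from adenosine receptor A2b (Homo sapiens), read by scintillation counting, with a stated time of 30 min, tested at 1 uM; a higher number here means more inhibition at the concentration tested (going by the name of the read-out), a lower number less inhibition:
compound 1 `COC(=O)C1=C(C)NC(=O)NC1c1ccoc1` gives 42%;
compound 2 `CCCC(=O)C1=C(C)NC(=O)NC1c1ccoc1` gives 22%;
compound 3 `CCCC(=O)C1=C(C)NC(=O)NC1c1ccsc1` gives 9%.

Compound 2 holds the second highest of the three numbers in this assay. It is separated from compound 1 by the step of a number 20 percentage points lower from compound 1 to compound 2 (beyond the scatter) and from compound 3 by the step of a number 13 percentage points lower from compound 2 to compound 3 (beyond the scatter), both beyond the scatter.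

Compound 4 `CCNC(=O)C1=C(C)NC(=O)NC1c1ccoc1` has not been measured in this assay. Its difference from compound 2: ethylamino in place of propyl on a carbonyl carbon. Among the compounds with values here, only one measured step touches the same carbonyl carbon, a number 20 percentage points lower from compound 1 to compound 2 (beyond the scatter), where methoxy gave the higher number and propyl the lower; that step was modest. The step of a number 13 percentage points lower from compound 2 to compound 3 (beyond the scatter) concerns a different place and says nothing about the carbonyl substituent. No amide has been measured in this series, so the direction rests on a single comparison. Because compound 1 with methoxy on the carbonyl carbon gives 42%, an ethylamino there is expected to move the number upward by a modest step, a number 10 percentage points higher from compound 2 to compound 4 (within the scatter), with a wide range. Compound 4 is therefore estimated at 32% in this assay, between 12% and 52%.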

Compound 4, a percentage reported as inhibition, at one concentration (the size of the read-out at that concentration, not a potency): 2%
For compound 4 the middle estimate is 30 percentage points above the measured one, outside the stated range (below it).
By their numbers in this assay, from the lowest: compounds 4 and 3 (each within the scatter of the next); then compound 2; then compound 1.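

In this assay the carbonyl carbon proves sensitive to an exchange that keeps the count of heavy atoms: ethylamino for propyl gives a number 20 percentage points lower from compound 2 to compound 4 (beyond the scatter) while ethylamino for methoxy gives a number 40 percentage points lower from compound 1 to compound 4 (beyond the scatter) on the same core. The three groups on this carbon now stand in the order methoxy, propyl, ethylamino with every step beyond the scatter, so a heteroatom attached to the carbonyl does not by itself go with the higher number, as the ethylamino group replaces a carbon of propyl with nitrogen and still ends lowest. No measurement at hand explains this order.

Open, from the compounds shown here alone, is whether dimethylamino, which has no amide hydrogen, or ethoxy on the same carbonyl carbon would follow ethylamino or methoxy. Also open, going by these compounds, is whether the order of the three groups holds with thiophen-3-yl in place of furan-3-yl.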